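Working notes: removing the ring-nitrogen substituent in a small series

The compounds below may be only part of what the source reports. "The series", "measured", "known", "first", "only" and "open" are said of these compounds alone.

The shared core is carried by compound 1 `N#Cc1c[nH]c2ncnc(N)c12`, compound 2 `COCCOCn1cc(C#N)c2c(N)ncnc21`, compound 3 `COCCOCn1cc(C(N)=S)c2c(N)ncnc21` and compound 4 `NC(=S)c1c[nH]c2ncnc(N)c12`, the last of which has not yet been measured. In a functional assay on KB cells (Homo sapiens) for cytotoxicity (on this read-out higher numbers stand for weaker inhibition and lower numbers for stronger inhibition), compound 1 gives 18000 nM. Compound 2 returns only a limit in this assay, namely > 100000 nM. Compound 3 gives 183000 nM in this assay, the highest number among the measured pair.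

The change hydrogen in place of (2-methoxyethoxy)methyl on an aromatic nitrogen brought an at least 5.5-fold lower number from compound 2 to compound 1 (0.74 log units; beyond the scatter); the step can only be bounded because of the limit of > 100000 nM in this assay, at which 1 of the 3 values shown sits. The change a group of 3 heavy atoms (1 carbon, 1 nitrogen, 1 sulfur; no ring) in place of a group of 2 heavy atoms (1 carbon, 1 nitrogen; no ring), on an aromatic carbon gave a step that the limit leaves unreadable from compound 2 to compound 3.

The change hydrogen in place of (2-methoxyethoxy)methyl on an aromatic nitrogen is the same kind of change as that from compound 2 to compound 1; the place differs in that the ring atom bears a group of 3 heavy atoms rather than a cyano group (2 heavy atoms). From compound 3 to compound 4 a step of a 6.1-fold lower number from compound 3 to compound 4 (0.79 log units; beyond the scatter) is expected, resting on the size of an at least 5.5-fold lower number from compound 2 to compound 1 (0.74 log units; beyond the scatter). Compound 4 is estimated at 30000 nM, with a likely range from 8000 nM to 120000 nM.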

Compound 4, half-maximal inhibitory concentration: 25000 nM
Compound 4: middle estimate off by 1.2-fold (0.08 log units), on the high side; measured number inside the range.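

In this assay, hydrogen in place of (2-methoxyethoxy)methyl on the aromatic nitrogen gives a 7.3-fold lower number from compound 3 to compound 4 (0.86 log units; beyond the scatter) and so carries over to a second core in the same direction. Whether the size also carries over stays unsettled: the same change on two cores in this assay, an at least 5.5-fold lower number (0.74 log units; beyond the scatter) from compound 2 to compound 1 and a 7.3-fold lower number (0.86 log units; beyond the scatter) from compound 3 to compound 4; the limit leaves it open whether they differ. With hydrogen on the nitrogen, the exchange of groups on the aromatic carbon gives a 1.4-fold higher number from compound 1 to compound 4 (0.14 log units; within the scatter), whereas the matching step with (2-methoxyethoxy)methyl cannot be read.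

Open, as far as these compounds go, is whether methyl or a longer alkyl chain on the aromatic nitrogen would give a number nearer that of hydrogen or of (2-methoxyethoxy)methyl. Also open, from the compounds shown here alone, is whether the change carries over with an amine or a carboxylic acid on the aromatic carbon.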